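Inverting One Ring Stereocentre: Compound 3 to Compound 4

The source may report more compounds than this note shows. Statements on the series, on what has been measured and on what is new or still open speak of the compounds shown alone.

Three compounds share a core and differ at one saturated ring carbon. Compound 1 `CCC[C@@H](OC(C)=O)C1=C(Br)[C@@](C)(OC)OC1=O` gives 5.4 ug/mL in a functional assay on KB cells (Homo sapiens) for cytotoxicity; a lower number here means that less compound is needed, a higher number that more compound is needed for the effect. Compound 2 `CCC[C@@H](OC(C)=O)C1=C(Br)[C@@](CI)(OC)OC1=O` gives 2.4 ug/mL in this assay, and compound 3 `CCC[C@@H](OC(C)=O)C1=C(Br)[C@@](OC)(C(Br)Br)OC1=O` gives 4.1 ug/mL. Among these three numbers compound 3 stands second highest: nearest to it is compound 1, within the scatter, and furthest is compound 2, also within the scatter. Going by the values given here, the only step beyond the scatter is a 2.3-fold lower number from compound 1 to compound 2 (0.35 log units; beyond the scatter), which goes with iodo in place of hydrogen on a saturated chain carbon bound to a saturated ring carbon. Compound 4 `CCC[C@@H](OC(C)=O)C1=C(Br)[C@](OC)(C(Br)Br)OC1=O` differs from compound 3 in configuration alone: the two compounds have the same atoms and bonds and differ only in configuration as drawn: 1 of 2 stereo elements differ; a stereocentre at a saturated ring carbon is drawn S in compound 3 and R in compound 4. Among the compounds with values here, no measured step involves a change of configuration, so the step from compound 1 to compound 2 does not bear on this change, and no step beyond the scatter is expected in this assay. For compound 4 the expected value is therefore 4.1 ug/mL, within a range from 1.5 ug/mL to 11 ug/mL. This corresponds to an expected step of no change at the digits printed from compound 3 to compound 4 (within the scatter).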

Compound 4, concentration for half-maximal effect: 6.1 ug/mL
Beside the measured number, compound 4's estimate is 1.5-fold (0.17 log units) below it; the range from low to high includes it.
By their numbers in this assay, from the lowest: compounds 2, 3, 1 and 4 (each within the scatter of the next, the first and the last beyond it).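

In this assay, inverting the ring stereocentre gives a 1.5-fold higher number from compound 3 to compound 4 (0.17 log units; within the scatter), so at this saturated ring carbon the change from S to R has no effect that can be told from the scatter, at least with dibromomethyl on that carbon. This pair isolates the stereocentre, as nothing else separates the two compounds: the fact that compounds 3 and 4 differ only in the configuration as drawn

The other two steps, both with dibromomethyl entering, differ in what they show: replacing iodomethyl gives a 2.5-fold higher number from compound 2 to compound 4 (0.41 log units; beyond the scatter), whereas replacing methyl gives a 1.1-fold higher number from compound 1 to compound 4 (0.05 log units; within the scatter).

As far as these compounds go, whether the inversion would remain this small with iodomethyl, or with an aminomethyl group or a carboxylic acid on the same carbon, stays open. The compounds shown also leave open what inverting the second stereocentre, on the chain, would do to the number in this assay.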